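A few compounds are considered here, and "the series" means these few. Any claim that something is new, unique, unknown or untested is made for them only; others in the source may bear on it.

Measured so far in a functional assay on U-251 cells (Homo sapiens) for inhibition, read by MTT assay, with a stated time of 2 days; on this read-out higher numbers stand for lower toxicity in this test and lower numbers for higher toxicity in this test:
- compound 1 (`Nc1ccccc1NC(=O)CCCNCC(=O)Nc1ccc(Cl)cc1`): > 100000 nM
- compound 2 (`Nc1ccccc1NC(=O)c1ccc(NCC(=O)Nc2cccc([N+](=O)[O-])c2)cc1`): > 100000 nM
- compound 3 (`COc1ccc(NC(=O)CNc2ccc(C(=O)Nc3ccccc3N)cc2)cc1`): > 100000 nM

Compound 1 stands only at a limit, and the series offers no number to rank it against (the limit of > 100000 nM in this assay, at which 3 of the 3 values shown sit).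

Compound 4 (`COc1ccc(NC(=O)CNCCCC(=O)Nc2ccccc2N)cc1`) differs from compound 1 in one group (methoxy in place of chloro on an aromatic carbon): methoxy in place of chloro on an aromatic carbon, para to a large group.

For the measured compounds named here, the one measured step bearing on this change also brings in 4-methoxyphenyl, but it gives no size (a step that the two limits leave unreadable from compound 2 to compound 3). Compound 3 carries that group and still sits at a limit (> 100000 nM).

No step beyond the scatter is therefore expected in this assay, and no direction can be assigned. The expected step is small (a number no higher from compound 1 to compound 4 (the limit leaves the size open)).

Compound 4 is estimated at about 100000 nM (expected range 50000 nM to 200000 nM), and most likely it will again be reported only as a limit.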

Compound 4, concentration lethal to 50% of the cells: > 100000 nM
Compound 4: only a limit was reported; the forecaster's own chance of this, stated with the estimate: 85%; the middle value sits exactly at the limit.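

Compound 1 and compound 4 both sit at a limit, so no step between them can be read: the limit of > 100000 nM in this assay, at which 4 of the 4 values shown sit.

The compounds shown leave open whether 4-methoxyphenyl and 4-chlorophenyl differ at all in this assay.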